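Two halogens leave, one bromine enters on the aryl ether

This account rests on a few compounds, and the source may have more. Where it says the series, first, only, none or still open, it means among the compounds named here.

Compound 1 `NC1=NC2(CCOCC2)N(OCCCOc2ccc(Cl)c(Cl)c2)C(N)=N1`: 590 nM
Compound 2 `NC1=NC2(CCSCC2)N(OCCCOc2cccc(Cl)c2Cl)C(N)=N1`: 1 nM
Compound 3 `NC1=NC2(CCOCC2)N(OCCCOc2ccc(Cl)cc2)C(N)=N1`: "not determined" (no result reported)

In a functional assay on MDA-MB-231 cells (Homo sapiens) for antiproliferative activity, read by MTT assay, with a stated time of 72 h (a higher number here means a weaker inhibitor, a lower number a stronger inhibitor), compound 2 gives 1 nM, the lowest of the two numbers that were obtained. Compound 1 gives 590 nM, a markedly higher number that lies beyond the scatter, but compound 1 and compound 2 differ in more than one place, so the two values are simply what they show. For compound 3 the entry reads "not determined" (no result reported).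

Compound 4 `NC1=NC2(CCSCC2)N(OCCCOc2ccccc2Br)C(N)=N1` has not yet been measured in this assay. It keeps the core of compound 2 and differs only in the aryl ether:

2-bromophenyl in place of 2,3-dichlorophenyl on an oxygen on a saturated carbon

Nothing measured here isolates this change, so the expectation rests on compound 2 alone. Compound 4 is expected to give about 5 nM, within a range from 1 nM to 30 nM. The step of a 5.0-fold higher number from compound 2 to compound 4 (0.70 log units; beyond the scatter) is expected to be a modest rise in the number, close to the edge of the scatter.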

Compound 4, half-maximal inhibitory concentration: 10 nM
Compound 4: the middle estimate sits 2.0-fold (0.30 log units) below what was measured, and the stated range covers the measured number.
By their numbers in this assay, from the lowest: compound 2; then compound 4; then compound 1.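

On the core of compound 2, putting 2-bromophenyl in place of 2,3-dichlorophenyl on an oxygen on a saturated carbon gives, in this assay, a 10-fold higher number from compound 2 to compound 4 (1.00 log units; beyond the scatter). Among these compounds, this is the first comparison here in which only one place changes, and it shows that this aryl ether affects the number beyond the scatter, yet with two chlorine atoms gone and one bromine in their stead the step remains modest. Nothing given here accounts for the size of this step.

The single step changes the halogen and the number of halogens together, so the compounds shown do not separate these two parts of the change. From the compounds shown here alone, how 2-chlorophenyl, unsubstituted phenyl or a ring carrying a methoxy group would compare on this core remains open, as does the effect of a longer chain on the oxygen.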